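Swapping a Heptyl Chain for Cyclohexyl on Two Related Cores

The source may report more compounds than this note shows. Statements on the series, on what has been measured and on what is new or still open speak of the compounds shown alone.

Four compounds are compared here. Compound 1 `CCCCCCC[C@H]1C[C@H](Cl)CCN1S(=O)(=O)c1ccc(C)cc1` carries a heptyl chain on a saturated ring carbon, and in compound 2 `Cc1ccc(S(=O)(=O)N2CC[C@@H](Cl)C[C@@H]2C2CCCCC2)cc1` a cyclohexyl stands in its place. Compound 3 `CCCCCCCC1C=C(Cl)CCN1S(=O)(=O)c1ccc(C)cc1` again bears the heptyl chain, but its core differs from that of compound 1, and the difference between the two cores is not broken down here. Compound 4 `Cc1ccc(S(=O)(=O)N2CCC(Cl)=CC2C2CCCCC2)cc1` puts the cyclohexyl on the core of compound 3 and has not yet been measured.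

In a functional assay on SW1573 cells (Homo sapiens) for antiproliferative activity, read by sulforhodamine B assay, with a stated time of 48 h (a lower number here means a stronger inhibitor of growth, a higher number a weaker inhibitor of growth), compound 1 gives > 100000 nM, which is a limit of the assay and not a number. Compound 1 thus sits at the limit of > 100000 nM in this assay, at which 1 of the 3 values shown sits, and gives no number. In this assay compound 2 gives 53000 nM. The change cyclohexyl in place of heptyl on a saturated ring carbon therefore produced an at least 1.8-fold lower number from compound 1 to compound 2 (0.27 log units; that floor lies within the scatter). In this assay compound 3 gives 49000 nM, and its value and that of compound 2 lie within the scatter of each other.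

The change from compound 3 to compound 4 is the same change, (cyclohexyl in place of heptyl on a saturated ring carbon), made on the other core. Compound 3 already gives a number rather than a limit, so there is less room for the cyclohexyl to show a gain. The step to compound 4 is expected to be a 1.4-fold lower number from compound 3 to compound 4 (0.15 log units; within the scatter), resting on the earlier step of an at least 1.8-fold lower number from compound 1 to compound 2 (0.27 log units; that floor lies within the scatter) measured from compound 1, whose floor lies within the scatter. Compound 4 is therefore estimated at 35000 nM, expected to fall between 15000 nM and 90000 nM.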

Compound 4, concentration for 50% growth inhibition: 62000 nM
Beside the measured number, compound 4's estimate is 1.8-fold (0.25 log units) below it; low and high end bracket the measured number.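

In this assay, the swap of cyclohexyl for heptyl on the core of compound 3 gives a 1.3-fold higher number from compound 3 to compound 4 (0.10 log units; within the scatter), so on this core the two groups cannot be told apart. This shows that no gain from the swap can be claimed on this core, but it does not show that the swap behaves differently on the two cores, and the comparison stays undecided: the same change on two cores in this assay, an at least 1.8-fold lower number (0.27 log units; that floor lies within the scatter) from compound 1 to compound 2 and a 1.3-fold higher number (0.10 log units; within the scatter) from compound 3 to compound 4; the limit leaves it open whether they differ. The weak point in that comparison is compound 1, whose entry is a limit of the assay and not a number: the limit of > 100000 nM in this assay, at which 1 of the 4 values shown sits.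

The compounds shown leave open whether any other group on the saturated ring carbon next to the ring nitrogen, such as a phenyl ring, a shorter butyl chain or an amine, would move the number by more than the usual scatter on either core. They also leave open whether a bromo group in place of the chloro group would change the picture, and whether the same swap would read the same way in a second cell line.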